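From hydroxymethyl to acetoxymethyl on compound 3

This account rests on a few compounds, and the source may have more. Where it says the series, first, only, none or still open, it means among the compounds named here.

For the measured compounds named here, compound 3 `CCOC(=O)C#Cc1c(C(=O)OCC)nnn1[C@@H]1O[C@H](CO)[C@@H](OC(C)C)[C@H]1OC(C)C` gives 370 nM in a functional assay on K562 cells (Homo sapiens), read by XTT assay, with a stated time of 48 h (on this read-out lower numbers stand for stronger inhibition and higher numbers for weaker inhibition), the only true number in this small set. Compound 1 `CCOC(=O)c1nnn([C@@H]2O[C@H](COC(C)=O)[C@@H](OC(C)=O)[C@H]2OC(C)=O)c1I` reads > 10000 nM, which is a limit of the assay. Compound 2 `CCOC(=O)c1nnn([C@@H]2O[C@H](COC(C)=O)[C@@H](OC(C)=O)[C@H]2OC(C)=O)c1-c1cccs1` reads > 10000 nM, again a limit. Compound 4 `CCOC(=O)C#Cc1c(C(=O)OCC)nnn1[C@@H]1O[C@H](COC(C)=O)[C@@H](OC(C)C)[C@H]1OC(C)C` departs from compound 3 by one change: acetyl in place of hydrogen on an oxygen on a saturated carbon, that is, hydroxymethyl to acetoxymethyl. Going by the values given here, the one measured step, a step that the two limits leave unreadable from compound 1 to compound 2, concerns a different group and has no readable size, so it offers nothing to carry over. From the compounds shown here alone, with no measured guide, no step beyond the usual scatter is expected in this assay, and the direction stays open. The expected change is a 1.4-fold higher number from compound 3 to compound 4 (0.13 log units; within the scatter). For compound 4 the estimated value is 500 nM, within an expected range of 120 nM to 2500 nM.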

Compound 4, half-maximal inhibitory concentration: 500 nM
For compound 4 middle estimate and measured number coincide at the digits printed, within the range that was stated.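

In this assay, acetyl on the hydroxy oxygen of the hydroxymethyl group gives a 1.4-fold higher number from compound 3 to compound 4 (0.13 log units; within the scatter), so at this position the hydrogen can be replaced with no step beyond the scatter. This is the first readable step among these compounds, since the earlier step cannot be read because both of its compounds sit at a limit: the limit of > 10000 nM in this assay, at which 2 of the 4 values shown sit.

From the compounds shown here alone, whether a longer acyl chain or a benzoyl group on this oxygen would leave the number as little moved stays open. So does the effect of an amine or a carboxylic acid at this position.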